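The source may hold more compounds than are shown below. What is called first, only, known or untested is meant among the compounds shown, and "the series" means these compounds.

Measured so far in an assay on isolated protein for inhibition of proto-oncogene tyrosine-protein kinase receptor Ret variant V804L (Homo sapiens), read by 33P incorporation, with stated times of 15 min and 40 min; on this read-out higher numbers stand for weaker inhibition and lower numbers for stronger inhibition:

compound 1, `O=C(Nc1ccc(Br)cc1)Nc1ccc(Nc2ncnc3c2OCCN3)cc1`: > 10000 nM, which is a limit of the assay, not a number
compound 2, `Cc1ccc(F)c(NC(=O)Nc2ccc(Nc3ncnc4c3OCCN4)cc2)c1`: 7000 nM

For the measured compounds named here, compound 2 holds the only number in this assay; the other value shown is a limit, as in the limit of > 10000 nM in this assay, at which 1 of the 2 values shown sits. Going by the values given here, the one measured step, an at least 1.4-fold lower number from compound 1 to compound 2 (0.15 log units; that floor lies within the scatter), changes the aryl group on the amide-type nitrogen of the urea and reaches only the floor of the limit, so it says nothing beyond the scatter.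

Compound 3, `CC(C)(C)c1cc(NC(=O)Nc2ccc(Nc3ncnc4c3OCCN4)cc2)no1`, carries the change (5-(tert-butyl)-1,2-oxazol-3-yl in place of 2-fluoro-5-methylphenyl on an amide-type nitrogen). Among the compounds with values here, this is again a swap of the group on the amide-type nitrogen, and the only step that bears on such a swap is the one from compound 1 to compound 2, which stayed within the scatter. Within the data shown here, no measured step supports a large move in either direction in this assay, so the expectation for compound 3 is a step of a 1.4-fold lower number from compound 2 to compound 3 (0.15 log units; within the scatter), not resolved from the scatter.

Compound 3 is estimated at 5000 nM in this assay, with a range from 1500 nM to 15000 nM.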

Compound 3, half-maximal inhibitory concentration: 58 nM
Compound 3: the middle estimate sits 86-fold (1.94 log units) above what was measured; measured number outside the range, below it.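

In this assay, the group on the amide-type nitrogen now proves able to move the number far beyond the scatter, which the phenyl-to-phenyl step could not show: a 120-fold lower number from compound 2 to compound 3 (2.08 log units; beyond the scatter). Measured against the 4-bromophenyl group, the 5-(tert-butyl)-1,2-oxazol-3-yl group also gives a large change, with an at least 170-fold lower number from compound 1 to compound 3 (2.23 log units; beyond the scatter). The reading for compound 1, > 10000 nM, is a limit of the assay and not a number, so that step is a floor only: the limit of > 10000 nM in this assay, at which 1 of the 3 values shown sits.

The compounds shown do not separate the contribution of the five-membered aromatic ring with its 2 hetero atoms from that of the tert-butyl group, since both enter together in compound 3, so it remains open whether a phenyl ring carrying tert-butyl, or the 1,2-oxazol-3-yl ring carrying methyl or trifluoromethyl instead, would keep the gain. For the compounds shown here, also open is whether the step holds with any core other than the one shared by compound 1, compound 2 and compound 3.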